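A few compounds are considered here, and "the series" means these few. Any claim that something is new, unique, unknown or untested is made for them only; others in the source may bear on it.

Compound 1 `Cc1nc(-c2ccccc2)sc1C(=O)CSc1nc(N)c(C#N)c(-c2ccccc2)n1`: in a functional assay on U-87MG ATCC cells for antiproliferative activity against U-87 MG (Homo sapiens), read by MTT assay, with a stated time of 48 h, tested at 100 uM (on this read-out lower numbers stand for a stronger effect and higher numbers for a weaker effect at the one concentration tested), compound 1 gives 6.48%.
Compound 2 `Cc1nc(-c2ccc(Cl)cc2)sc1C(=O)CSc1nc(N)c(C#N)c(-c2ccc(Cl)cc2)n1`: in this assay compound 2 gives 1.65%.
Compound 3 `COc1ccc(-c2nc(SCC(=O)c3sc(-c4ccc(Cl)cc4)nc3C)nc(N)c2C#N)cc1`: in this assay compound 3 gives 0.79%.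

Compound 3 shows the lowest of the three numbers, but its gaps to compound 2 and to compound 1 both lie within the scatter, so no order among the three can be claimed. Compound 4 `Cc1nc(-c2ccc(Cl)cc2)sc1C(=O)CSc1nc(N)c(C#N)c(-c2ccccc2)n1` differs from compound 3 by hydrogen in place of methoxy on an aromatic carbon. Within the data shown here, only one measured step touches this part of the molecule: a number 0.9 percentage points lower from compound 2 to compound 3 (within the scatter), a change at the same aromatic carbon that stayed within the scatter. Compound 1, which also carries the plain phenyl on that side, gives a number within the scatter of compound 3. No step beyond the scatter is therefore expected in this assay for compound 4, whose value is estimated at 2.5% (range 0% to 9%), an expected step of a number 1.7 percentage points higher from compound 3 to compound 4 (within the scatter).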

Compound 4, a percentage reported as activity, at one concentration (the size of the read-out at that concentration, not a potency): 4.59%
The estimate for compound 4 lay 2.1 percentage points below the measured number, and the stated range covers the measured number.
By their numbers in this assay, from the lowest: compounds 3, 2, 4 and 1 (each within the scatter of the next).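

In this assay the plain phenyl at this position cannot be told apart from the substituted rings, since hydrogen in place of methoxy gives a number 3.8 percentage points higher from compound 3 to compound 4 (within the scatter) and hydrogen in place of chloro gives a number 2.9 percentage points higher from compound 2 to compound 4 (within the scatter) at the same carbon. Chloro in place of hydrogen at a second aromatic carbon gives a number 1.9 percentage points lower from compound 1 to compound 4 (within the scatter) and is equally unresolved. Nothing measured here bears on the cause of these numbers.

As far as these compounds go, whether an amine or a carboxylic acid at this carbon would give a step beyond the scatter remains open. A single concentration also shows the effect of all four compounds at that concentration only.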